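The compounds below may be only part of what the source reports. "The series", "measured", "known", "first", "only" and "open" are said of these compounds alone.

Measured compounds in a functional assay on MCF7 cells (Homo sapiens) for antiproliferative activity, read by XTT assay, with a stated time of 72 h; on this read-out higher numbers stand for weaker inhibition and lower numbers for stronger inhibition:
- compound 1 `COc1ccc(-c2cc3ccccc3nc2/C=C/C(=O)c2ccccc2)cc1` gives 4040 nM
- compound 2 `COc1ccc(-c2cc3ccccc3nc2/C=C/C(=O)c2c(OC)cccc2OC)cc1` gives 4520 nM

Compound 2 holds the higher of the two numbers, though its separation from compound 1 is within the scatter, so the two are not ranked. Among the compounds with values here, the only step recorded so far, a 1.1-fold higher number from compound 1 to compound 2 (0.05 log units; within the scatter), exchanged the group on the carbonyl carbon and moved the number by an amount inside the scatter.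

Compound 3 `COc1ccc(-c2cc3ccccc3nc2/C=C/C(=O)c2ccc(N)cc2)cc1` is not yet measured. It differs from compound 2 by 4-aminophenyl in place of 2,6-dimethoxyphenyl on a carbonyl carbon. The step from compound 1 to compound 2 is the only one that bears on this change, since it altered the same ring on the same carbonyl carbon, and it was flat. A single flat step gives little footing; a step of modest size in either direction, or none beyond the scatter, is the expectation in this assay. The estimate for compound 3 is 3500 nM, range 1200 nM to 10000 nM, which means an expected step of a 1.3-fold lower number from compound 2 to compound 3 (0.11 log units; within the scatter).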

Compound 3, half-maximal inhibitory concentration: 6920 nM
For compound 3 the middle estimate is 2.0-fold (0.30 log units) below the measured one, within the range that was stated.
By their numbers in this assay, from the lowest: compounds 1, 2 and 3 (each within the scatter of the next).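

In this assay the exchange of 2,6-dimethoxyphenyl for 4-aminophenyl on a carbonyl carbon gives a 1.5-fold higher number from compound 2 to compound 3 (0.18 log units; within the scatter) and so brings a hydrogen-bond donor to this position without a step that can be separated from the scatter. Within the data shown here, the smaller change, amino in place of hydrogen on an aromatic carbon, gives a 1.7-fold higher number from compound 1 to compound 3 (0.23 log units; within the scatter) and so leaves phenyl, 2,6-dimethoxyphenyl and 4-aminophenyl unranked, with no step at this position yet beyond the scatter. No supporting data bear on what lies behind these numbers.

On these data alone, whether a different kind of group on this ring, such as a carboxylic acid or a nitrile, would move the number beyond the scatter stays open. So does the effect of a change elsewhere, such as a hydroxyl in place of the methoxy group on the shared core.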